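A Methyl Group Gives Way to Hydrogen

The compounds below may be only part of what the source reports. "The series", "measured", "known", "first", "only" and "open" are said of these compounds alone.

In a functional assay on HeLa cells (Homo sapiens) for antiproliferative activity, read by sulforhodamine B assay, with a stated time of 48 h (on this read-out higher numbers stand for weaker inhibition and lower numbers for stronger inhibition), compound 1 (`COc1cc(OC)c2sc(-c3ccc(N/C=C\C(=O)c4ccc(OC)c([N+](=O)[O-])c4)cc3)nc2c1`) gives 12900 nM. Compound 2 (`COc1cc(OC)c2sc(-c3ccc(N/C=C\C(=O)c4cc(OC)c(OC)c(OC)c4)c(C)c3)nc2c1`) gives 16400 nM, which stands within the scatter of the value of compound 1. Compound 3 (`COc1cc(OC)c2sc(-c3ccc(N/C=C\C(=O)c4cc(OC)c(OC)c(OC)c4)cc3)nc2c1`) is not yet measured. It has hydrogen in place of methyl on an aromatic carbon of compound 2 (hydrogen in place of methyl on an aromatic carbon). For the measured compounds named here, no measured pair shows this change, so only a small shift towards a lower number, within the scatter, is expected in this assay. The expected change is a 1.5-fold lower number from compound 2 to compound 3 (0.17 log units; within the scatter). For compound 3 the estimated value is 11000 nM, in an expected range of 3500 nM to 30000 nM.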

Compound 3, half-maximal inhibitory concentration: 17800 nM
The estimate for compound 3 lay 1.6-fold (0.21 log units) below the measured number; the range from low to high includes it.
By their numbers in this assay, from the lowest: compounds 1, 2 and 3 (each within the scatter of the next).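

Hydrogen in place of methyl on this aromatic carbon, ortho to a large group and meta to a large group, gives a 1.1-fold higher number from compound 2 to compound 3 (0.04 log units; within the scatter), so this assay does not tell the two groups apart at this place. 3,4,5-trimethoxyphenyl in place of 4-methoxy-3-nitrophenyl on a carbonyl carbon gives a 1.4-fold higher number from compound 1 to compound 3 (0.14 log units; within the scatter), so that exchange cannot be told apart either. Nothing at hand offers an explanation for these results.

The compounds shown leave open whether an amine, a carboxylic acid or a longer chain at this place would also stay within the scatter. They also leave open whether the methyl would behave the same way on compound 1.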